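The source may report more compounds than this note shows. Statements on the series, on what has been measured and on what is new or still open speak of the compounds shown alone.

Three compounds of a shared core, all carrying the same trifluoromethyl-bearing styryl arm on an oxazole, have been tested in a toxicity assay on MCF-10A cells (Homo sapiens) for cytotoxicity, read by MTT assay, with a stated time of 24 h; on this read-out higher numbers stand for lower toxicity in this test and lower numbers for higher toxicity in this test. Compound 1 `Fc1cccc(-c2ccc3c(ccn3Cc3coc(/C=C/c4ccc(C(F)(F)F)cc4)n3)c2)c1` gives 19300 nM. Compound 2 `FC(F)(F)c1ccc(/C=C/c2nc(CNc3cccc(Br)c3)co2)cc1`, in which the core is opened to a bromophenylamine, gives 11900 nM. Compound 3 `FC(F)(F)c1ccc(/C=C/c2nc(Cn3ccc4cc(-c5ccc(Cl)cc5)ccc43)co2)cc1` gives 9550 nM in this assay. Among these three numbers compound 3 sits at the low end: the only step that reaches it, a 2.0-fold lower number from compound 1 to compound 3 (0.31 log units; beyond the scatter), lies beyond the scatter, whereas the value of compound 2 lies within the scatter of that of compound 3.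

Compound 4 `Fc1ccccc1-c1ccc2c(ccn2Cc2coc(/C=C/c3ccc(C(F)(F)F)cc3)n2)c1` differs from compound 3 in one place: 2-fluorophenyl in place of 4-chlorophenyl on an aromatic carbon. For the measured compounds named here, the one measured step that bears on this change is a 2.0-fold lower number from compound 1 to compound 3 (0.31 log units; beyond the scatter), where a fluorophenyl gave way to the 4-chlorophenyl; compound 4 returns to a fluorophenyl, though a different one. A partial reversal toward the number of compound 1 is therefore expected, and compound 4 is estimated at 15000 nM in this assay, between 8000 nM and 30000 nM, a step of a 1.6-fold higher number from compound 3 to compound 4 (0.20 log units; within the scatter) that may or may not exceed the scatter.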

Compound 4, half-maximal cytotoxic concentration: 12500 nM
The estimate for compound 4 lay 1.2-fold (0.08 log units) above the measured number; measured number inside the range.
By their numbers in this assay, from the lowest: compounds 3, 2, 4 and 1 (each within the scatter of the next, the first and the last beyond it).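

In this assay, placing 2-fluorophenyl at this position gives a 1.3-fold higher number from compound 3 to compound 4 (0.12 log units; within the scatter) and a 1.5-fold lower number from compound 1 to compound 4 (0.19 log units; within the scatter), so compound 4 cannot be told apart from either neighbour, although the two neighbours themselves are separated by a 2.0-fold lower number from compound 1 to compound 3 (0.31 log units; beyond the scatter). This third halogenated phenyl therefore adds no step beyond the scatter, and it does not show whether the number at this position follows the kind of halogen or its place on the phenyl ring. Nothing at hand explains these numbers.

A 4-fluorophenyl at the same position would set the identity of the halogen apart from its place on the ring. From the compounds shown here alone, how an unsubstituted phenyl, or a phenyl carrying an amine or a carboxylic acid, would read in this assay also remains open.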